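The source may hold more compounds than are shown below. What is called first, only, known or untested is meant among the compounds shown, and "the series" means these compounds.

Compound 1 `O=C(C1=C(Nc2ccccc2)C(=O)N(CCCn2ccnc2)C1c1ccc(Br)cc1)c1ccccc1` gives 21200 nM in a functional assay on NCI-H1299 cells (Homo sapiens) for antiproliferative activity, read by MTT assay, with a stated time of 72 h; a higher number here means a weaker inhibitor, a lower number a stronger inhibitor. Compound 2 `O=C(C1=C(Nc2ccc(F)cc2)C(=O)N(CCCn2ccnc2)C1c1ccc(Br)cc1)c1ccccc1` gives 25400 nM in this assay, and the change a 1.2-fold higher number from compound 1 to compound 2 (0.08 log units; within the scatter) stays within the scatter, so compound 2 has the higher of the two numbers without being separable from compound 1. Compound 3 `O=C(C1=C(Nc2ccc(I)cc2)C(=O)N(CCCn2ccnc2)C1c1ccc(Br)cc1)c1ccccc1` differs from compound 2 by iodo in place of fluoro on an aromatic carbon. Going by the values given here, the only measured step touches the same position and was small, and no step shows iodo, so a step of size a 1.1-fold lower number from compound 2 to compound 3 (0.02 log units; within the scatter) within the scatter is expected. Compound 3 is estimated at 24000 nM, between 9000 nM and 65000 nM.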

Compound 3, half-maximal inhibitory concentration: 19400 nM
Compound 3: the middle estimate sits 1.2-fold (0.09 log units) above what was measured; the range from low to high includes it.
By their numbers in this assay, from the lowest: compounds 3, 1 and 2 (each within the scatter of the next).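

With iodo at this place, para to a large group, the change from fluoro gives a 1.3-fold lower number from compound 2 to compound 3 (0.12 log units; within the scatter), and the change from hydrogen gives a 1.1-fold lower number from compound 1 to compound 3 (0.04 log units; within the scatter). Hydrogen, fluoro and iodo on this aromatic carbon therefore cannot be told apart in this assay, so three quite different atoms now give the same reading, where the earlier pair covered only two. No measurement shown here offers an explanation for this. Still open, from the compounds shown here alone, is whether an amine or a carboxylic acid at this place would shift the number beyond the scatter.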